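A few compounds are considered here, and "the series" means these few. Any claim that something is new, unique, unknown or untested is made for them only; others in the source may bear on it.

Series notes. The shared core is that of compound 1 `O=C1/C(=C\c2cccc(Oc3ccccc3)c2)c2ccccc2N1c1c(Cl)cccc1Cl`, compound 2 `O=C1/C(=C\c2ccc(F)cc2)c2ccccc2N1c1c(Cl)cccc1Cl` and compound 3 `O=C1/C(=C\c2ccccc2[N+](=O)[O-])c2ccccc2N1c1c(Cl)cccc1Cl`, which differ only in the aryl group on the double-bonded chain carbon. In a functional assay on MIA PaCa-2 cells (Homo sapiens) for cytotoxicity, read by MTT assay, with a stated time of 72 h (a lower number here means that less compound is needed, a higher number that more compound is needed for the effect), compound 2 gives 5 ug/mL. Compound 3 gives 5 ug/mL in this assay. Compound 1 reaches only a limit, > 100 ug/mL, in this assay. Compound 3 thus stands level with compound 2, and the step of no change at the digits printed from compound 2 to compound 3 (within the scatter) lies within the scatter. Going by the values given here, the one other value in the set, (the limit of > 100 ug/mL in this assay, at which 1 of the 3 values shown sits), is a limit and not a number.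

Compound 4 `O=C1/C(=C\c2cccc(Cl)c2)c2ccccc2N1c1c(Cl)cccc1Cl` is not yet measured; it differs from compound 3 by 3-chlorophenyl in place of 2-nitrophenyl on a double-bonded chain carbon bound to a double-bonded ring carbon. Among the compounds with values here, the only measured step that bears on it is no change at the digits printed from compound 2 to compound 3 (within the scatter): exchanging one substituted aryl group for another on that carbon left the read-out unchanged. By analogy, the step of a 1.2-fold higher number from compound 3 to compound 4 (0.08 log units; within the scatter) is expected to stay within the scatter, with some widening of the range to allow for the untested chlorine substituent. Compound 4 is therefore estimated at 6 ug/mL, with a range of 2 ug/mL to 25 ug/mL in this assay.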

Compound 4, concentration for half-maximal effect: 5 ug/mL
The estimate for compound 4 lay 1.2-fold (0.08 log units) above the measured number, within the range that was stated.
By their numbers in this assay, from the lowest: compounds 2, 3 and 4 (each within the scatter of the next). At a limit, above all of these: compound 1.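

In this assay, the read-out shows no change at the digits printed from compound 3 to compound 4 (within the scatter) and no change at the digits printed from compound 2 to compound 4 (within the scatter), so 3-chlorophenyl sits level with 4-fluorophenyl and 2-nitrophenyl on a double-bonded chain carbon bound to a double-bonded ring carbon. The hydrogen-bond acceptors of 2-nitrophenyl are absent from 3-chlorophenyl, and the read-out still holds, so these acceptors are not needed for it among the compounds shown. Chloro in place of phenoxy gives the first step beyond the scatter at this place, an at least 20-fold lower number from compound 1 to compound 4 (1.30 log units; beyond the scatter), and compound 1 stands at a limit and not a number: the limit of > 100 ug/mL in this assay, at which 1 of the 4 values shown sits.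

On these data alone, it remains open whether this level survives an amine or a carboxylic acid on the aryl ring. Also open, as far as these compounds go, is whether a methoxy or benzyloxy group in place of phenoxy stays with compounds 2, 3 and 4 or moves towards compound 1.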